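Methylated piperazine on a longer chain

The source may hold more compounds than are shown below. What is called first, only, known or untested is meant among the compounds shown, and "the series" means these compounds.

In a functional assay on HCT-116 cells (Homo sapiens) for cytotoxicity, read by MTT assay, with a stated time of 72 h (a higher number here means a weaker inhibitor, a lower number a stronger inhibitor), compound 1 `CN1CCN(CCCCn2c3c(c4ccccc42)C(=O)c2c[n+]([O-])c4ccccc4c2C3=O)CC1` gives 10 nM, while compound 2 `O=C1c2c[n+]([O-])c3ccccc3c2C(=O)c2c1c1ccccc1n2CCCCN1CCNCC1` gives 700 nM, the higher of the two numbers. Compound 3 `CN1CCN(CCCCCCn2c3c(c4ccccc42)C(=O)c2c[n+]([O-])c4ccccc4c2C3=O)CC1` departs from compound 2 thus: 2-(4-methylpiperazin-1-yl)ethyl in place of piperazin-1-yl on a saturated chain carbon, four bonds along the chain from an aromatic nitrogen. For the measured compounds named here, the only measured step bearing on this is large: a 70-fold higher number from compound 1 to compound 2 (1.85 log units; beyond the scatter). It swaps methyl for hydrogen on the ring amine nitrogen, and compound 3 has the methyl, as 2-(4-methylpiperazin-1-yl)ethyl. Going by the values given here, no measured step covers the chain length, so the range stays wide. The expected step is large and downward, a 35-fold lower number from compound 2 to compound 3 (1.54 log units; beyond the scatter). For compound 3 the estimated value is 20 nM, within an expected range of 4 nM to 120 nM.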

Compound 3, half-maximal inhibitory concentration: 2900 nM
Beside the measured number, compound 3's estimate is 150-fold (2.16 log units) below it; measured number above the stated range.
By their numbers in this assay, from the lowest: compound 1; then compound 2; then compound 3.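

In this assay, the benefit of the methyl does not survive a longer chain: a 290-fold higher number from compound 1 to compound 3 (2.46 log units; beyond the scatter) follows when 2-(4-methylpiperazin-1-yl)ethyl replaces 4-methylpiperazin-1-yl on the saturated chain carbon. The longer methylated compound even falls behind the shorter unmethylated one, with a 4.1-fold higher number from compound 2 to compound 3 (0.62 log units; beyond the scatter) as the result. Nothing measured here explains this loss.

A pentyl chain would show whether the loss builds gradually or appears abruptly. From the compounds shown here alone, whether a morpholine in place of the 4-methylpiperazin-1-yl would keep the activity on the butyl chain also remains open.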